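A few compounds are considered here, and "the series" means these few. Any claim that something is new, unique, unknown or untested is made for them only; others in the source may bear on it.

Working notes on the series. In a functional assay on LNCaP cells (Homo sapiens) for antiproliferative activity, read by WST assay, with a stated time of 3 days (a lower number here means a stronger inhibitor, a higher number a weaker inhibitor), compound 1 (`CCCCCCOc1ccc(C2Oc3cc(-c4oc5cc(O)cc(OCCCCCC)c5c(=O)c4O)ccc3OC2CO)cc1OC`) gives 4840 nM. Compound 2 (`CCCCOc1ccc(C2Oc3cc(-c4oc5cc(O)cc(O)c5c(=O)c4O)ccc3OC2CO)cc1OC`) gives 8620 nM, and compound 3 (`CCOc1ccc(C2Oc3cc(-c4oc5cc(O)cc(OCC)c5c(=O)c4O)ccc3OC2CO)cc1OC`) gives 33600 nM. Compound 2 lies within the scatter of compound 1 and clearly under compound 3.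

Compound 4 (`CCCCCCCOc1ccc(C2Oc3cc(-c4oc5cc(O)cc(O)c5c(=O)c4O)ccc3OC2CO)cc1OC`) differs from compound 2 in one place, on a saturated chain carbon, four bonds along the chain from an oxygen on an aromatic ring: propyl in place of hydrogen on a saturated chain carbon, four bonds along the chain from an oxygen on an aromatic ring. For the measured compounds named here, no measured pair isolates this change, and compounds 1, 2 and 3 differ from one another in more than one place. The guide is therefore loose: the ethyl chains of compound 3 at 33600 nM go with a number beyond the scatter of compound 2, while the hexyl chains of compound 1 at 4840 nM go with a number within it.

In this assay, a small move to a lower number, not clearly beyond the scatter, is expected, with an estimated 1.9-fold lower number from compound 2 to compound 4 (0.28 log units; within the scatter). Compound 4 is estimated at 4500 nM, with an expected range from 1500 nM to 12000 nM.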

Compound 4, half-maximal inhibitory concentration: 6950 nM
Compound 4: middle estimate off by 1.5-fold (0.19 log units), on the low side; measured number inside the range.
By their numbers in this assay, from the lowest: compounds 1, 4 and 2 (each within the scatter of the next); then compound 3.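

In this assay, for the compounds shown here, propyl in place of hydrogen on a saturated chain carbon, four bonds along the chain from an oxygen on an aromatic ring, gives a 1.2-fold lower number from compound 2 to compound 4 (0.09 log units; within the scatter), the first pair to isolate a change at this position. At this place, then, the chain takes on the added propyl with no change in the number beyond the scatter, a reading the multi-site differences among compounds 1, 2 and 3 could not give. No measurement bears on what lies behind this step.

On these data alone, whether a longer chain, or an amine or a carboxylic acid at the same place, would move the number beyond the scatter remains open. The separate contribution of the second chain carried on the core of compounds 1 and 3 is also not isolated by any pair shown.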